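The compounds below may be only part of what the source reports. "The series", "measured", "known", "first", "only" and "open" are said of these compounds alone.

Compound 1 `Nc1nn(C(=O)Nc2ccc(Cc3ccccc3)cc2)c2ccccc12` and compound 2 `Nc1nn(C(=O)Nc2ccc(Cc3ccccc3)cc2)c2ccc(Cl)cc12` share one core and differ only in a chloro group on an aromatic carbon. In a functional assay on SN12C cells (Homo sapiens) for antiproliferative activity, read by sulforhodamine B assay, with a stated time of 48 h (on this read-out higher numbers stand for weaker inhibition of growth and lower numbers for stronger inhibition of growth), compound 1 gives 12900 nM, and compound 2 gives 14600 nM. Going by the values given here, the step of a 1.1-fold higher number from compound 1 to compound 2 (0.05 log units; within the scatter) leaves the two compounds indistinguishable on this read-out, so compound 2 stands at the same level as the only other measured compound. Compound 3 `Nc1ccc2c(c1)c(N)nn2C(=O)Nc1ccc(Cc2ccccc2)cc1` keeps the rest of compound 2 unchanged and carries the change (amino in place of chloro on an aromatic carbon). Among the compounds with values here, the single measured step, that from compound 1 to compound 2, bears on this change in so far as it also exchanged the group on this aromatic carbon, and it moved the number by an amount inside the scatter. Within the data shown here, no measured compound shows amino there, so nothing among the measured values points to a large shift in either direction in this assay; the expectation is a step of a 1.1-fold lower number from compound 2 to compound 3 (0.05 log units; within the scatter) that stays within the scatter. Compound 3 is therefore estimated at 13000 nM in this assay, with a range from 5500 nM to 32000 nM.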

Compound 3, concentration for 50% growth inhibition: 13400 nM
Estimate against measurement, compound 3: 1.0-fold (0.01 log units) below, and the stated range covers the measured number.
By their numbers in this assay, from the lowest: compounds 1, 3 and 2 (each within the scatter of the next).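

In this assay the step of a 1.1-fold lower number from compound 2 to compound 3 (0.04 log units; within the scatter) and the step of a 1.0-fold higher number from compound 1 to compound 3 (0.02 log units; within the scatter) both lie within the scatter, so this aromatic carbon has now been seen with hydrogen, chloro and amino without any of the three compounds standing apart. The earlier pair had shown this only for chloro and hydrogen, whereas amino adds a hydrogen-bond donor and a hydrogen-bond acceptor where chloro has neither, and this difference in the counts goes with no step beyond the scatter on this read-out. Nothing is available that would explain why the three compounds cannot be told apart at this position.

The compounds shown leave open whether another group on this carbon, such as a carboxylic acid, a methoxy group or a longer alkyl chain, would give a step beyond the scatter. They also leave open whether a change elsewhere in the shared structure would move the number, since all three compounds differ only at this one aromatic carbon.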